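From a Hydroxyphenyl to a Benzamido Group

The source may report more compounds than this note shows. Statements on the series, on what has been measured and on what is new or still open speak of the compounds shown alone.

Compound 1 `Cc1ccc(/N=C2\C(=O)Nc3ccc(S(=O)(=O)N4CCOCC4)cc32)cc1` gives 309000 nM
Compound 2 `O=C1Nc2ccc(S(=O)(=O)N3CCOCC3)cc2/C1=N/c1ccc(O)cc1` gives 259000 nM
Compound 3 `COc1ccc(-c2c(C#N)c(N)n(/N=C3\C(=O)Nc4ccc(S(=O)(=O)N5CCOCC5)cc43)c(=O)c2C#N)cc1` gives 224000 nM

These numbers come from an ADME assay on WI-38 cells (Homo sapiens) for cytotoxicity, read by sulforhodamine B assay, with a stated time of 24 h (a lower number here means a stronger inhibitor, a higher number a weaker inhibitor), and compound 2 at 259000 nM lies within the usual scatter of both other compounds. Compound 4 `O=C1Nc2ccc(S(=O)(=O)N3CCOCC3)cc2/C1=N/NC(=O)c1ccccc1` has not been measured yet. It differs from compound 2 in one place, with benzamido in place of 4-hydroxyphenyl on a double-bonded nitrogen while the rest of the structure stays the same.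

A step is the change in number between two compounds that differ in one place. For the measured compounds named here, the only measured step is a 1.2-fold lower number from compound 1 to compound 2 (0.08 log units; within the scatter) for hydroxy in place of methyl on an aromatic carbon, which is a different swap and so only a loose guide. Compound 3 also carries a different group on that double-bonded nitrogen, and at 224000 nM it sits in the same narrow band. No step beyond the scatter is therefore expected in this assay and no direction can be given. The estimated move is a 1.0-fold lower number from compound 2 to compound 4 (0.02 log units; within the scatter) and no more than that is expected. For compound 4 the expected value is 250000 nM with an estimated range of 130000 nM to 450000 nM for now.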

Compound 4, half-maximal inhibitory concentration: 295000 nM
Beside the measured number, compound 4's estimate is 1.2-fold (0.07 log units) below it; low and high end bracket the measured number.
By their numbers in this assay, from the lowest: compounds 3, 2, 4 and 1 (each within the scatter of the next).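

In this assay, the step for benzamido in place of 4-hydroxyphenyl on a double-bonded nitrogen is a 1.1-fold higher number from compound 2 to compound 4 (0.06 log units; within the scatter), and the step for benzamido in place of 4-methylphenyl is a 1.0-fold lower number from compound 1 to compound 4 (0.02 log units; within the scatter). For the compounds shown here, the earlier step changed only one small group on the aromatic ring, whereas these replace the whole group at this position, with 9 heavy atoms entering where 7 leave, and the number still stays within the scatter. No measurement here offers an explanation for this result.

As far as these compounds go, it remains open whether a carboxylic acid or an amine on the aromatic ring of the benzamido group, or a longer chain on that nitrogen, would give a step beyond the scatter. From the compounds shown here alone, whether these swaps would matter in any other test also remains open.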